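This account rests on a few compounds, and the source may have more. Where it says the series, first, only, none or still open, it means among the compounds named here.

Of the compounds shown here, three of one shared core have been tested in a functional assay on T-24 cells (Homo sapiens) for cytotoxicity, read by neutral red uptake, with a stated time of 72 h; a lower number here means a stronger inhibitor, a higher number a weaker inhibitor. Compound 1, `CCCCCCNc1nc(SCC)nc2ncccc12`, gives 5900 nM in this assay. Compound 2, `CCCCCCNc1nc(SC(C)C)nc2ncccc12`, gives 15800 nM. Compound 3, `CCCCCNc1nc(SCCCC)nc2ncccc12`, gives 8900 nM. Compound 4, `CCCCCCNc1nc(SCCCC)nc2ncccc12`, has not yet been measured.

Compound 2 differs from compound 1 by methyl in place of hydrogen on a saturated chain carbon bound to a saturated chain carbon and a sulfur, and this change produced a 2.7-fold higher number from compound 1 to compound 2 (0.43 log units; beyond the scatter). Compound 4 differs from compound 3 by methyl in place of hydrogen on a saturated chain carbon, five bonds along the chain from a nitrogen on an aromatic ring. The same group enters in both cases, so this is the same kind of change, yet the place is not the same: in the first pair the carbon is bound to a saturated chain carbon and a sulfur, while in the second pair it lies five bonds along the chain from a nitrogen on an aromatic ring. The difference between the core of compound 1 and the core of compound 3 is not broken down here; compound 3 and compound 1 give numbers within the usual scatter of each other.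

Going by the values given here, with only one earlier step, at a different place, to rest on, the step from compound 3 to compound 4 is expected to be small, near a 1.2-fold lower number from compound 3 to compound 4 (0.07 log units; within the scatter). Compound 4 is therefore estimated at about 7500 nM, with a likely range from 3000 nM to 20000 nM.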

Compound 4, half-maximal inhibitory concentration: 4500 nM
Compound 4: middle estimate off by 1.7-fold (0.22 log units), on the high side; the range from low to high includes it.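

In this assay, methyl in place of hydrogen did not carry the same result from one core to the other: the same change on two cores in this assay, a 2.7-fold higher number (0.43 log units; beyond the scatter) from compound 1 to compound 2 and a 2.0-fold lower number (0.30 log units; within the scatter) from compound 3 to compound 4, 5.3-fold (0.72 log units) apart, beyond the scatter of two such steps. The new step, a 2.0-fold lower number from compound 3 to compound 4 (0.30 log units; within the scatter) on its own, puts the methyl five bonds along the chain from a nitrogen on an aromatic ring, whereas the earlier methyl sits on a carbon bound to a sulfur, so these two pairs show that the earlier result cannot simply be carried over, but not whether the core or the place accounts for the gap. Among the other comparisons, butyl in place of isopropyl on a sulfur gives a 3.5-fold lower number from compound 2 to compound 4 (0.55 log units; beyond the scatter) and lies beyond the scatter, while ethyl in place of hydrogen two bonds along the chain from a sulfur gives a 1.3-fold lower number from compound 1 to compound 4 (0.12 log units; within the scatter) and lies within it.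

The compounds shown leave open whether methyl at a single place would behave alike on both cores. They also leave open how a chain longer than butyl on the sulfur, or an amine on that chain, would read.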